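Nitro removal on two unrelated cores

The source may hold more compounds than are shown below. What is called first, only, known or untested is meant among the compounds shown, and "the series" means these compounds.

Compound 1 `COc1ccc(-c2cc(=O)c3c(OC)cc(OC)cc3n2S(=O)(=O)c2ccc(C)c([N+](=O)[O-])c2)cc1` and compound 2 `COc1ccc(-c2cc(=O)c3c(OC)cc(OC)cc3n2S(=O)(=O)c2ccc(C)cc2)cc1` share one core. Compound 3 `COC(=O)c1cc(=O)c2cc(NC(=O)Nc3ccc(C(F)(F)F)cc3[N+](=O)[O-])ccc2[nH]1` rests on another core, and the difference between the two cores is not broken down here. In a functional assay on SUP-B15 cells (Homo sapiens) for antiproliferative activity, with a stated time of 72 h (a lower number here means that less compound is needed, a higher number that more compound is needed for the effect), compound 1 gives only a limit, > 51700 nM. In this assay compound 2 likewise gives only a limit, > 44800 nM. The change hydrogen in place of nitro on an aromatic carbon therefore reads as a step that the two limits leave unreadable from compound 1 to compound 2, both ends resting at the limit of > 44800 nM in this assay, at which 1 of the 3 values shown sits, and (the limit of > 51700 nM in this assay, at which 2 of the 3 values shown sit). In this assay compound 3 also gives only a limit, > 51700 nM. Compound 4 `COC(=O)c1cc(=O)c2cc(NC(=O)Nc3ccc(C(F)(F)F)cc3)ccc2[nH]1` carries the same kind of change, (hydrogen in place of nitro on an aromatic carbon), the place here being ortho to a large group and meta to a trifluoromethyl group rather than ortho to a methyl group and meta to a large group. With the step from compound 1 to compound 2 unreadable and compound 3 at a limit, the step that the limit leaves unreadable from compound 3 to compound 4 is expected to be near nil. Compound 4 is expected at 60000 nM, most likely reported again only as a limit.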

Compound 4, half-maximal effective concentration: 3270 nM
For compound 4 the middle estimate is 18-fold (1.26 log units) above the measured one; measured number below the stated range.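

In this assay hydrogen in place of nitro on an aromatic carbon gives an at least 15-fold lower number from compound 3 to compound 4 (1.19 log units; beyond the scatter) and so turns a limit into a measured value on the core of compound 3. On the core shared by compound 1 and compound 2 the same change cannot be read, as both ends are limits, so the data show neither that the change carries from one core to the other nor that it fails to. Nothing shown here accounts for the size of the step.

Open, on these data alone, is how an amine or a carboxylic acid in place of the nitro would read on the core of compound 4. Also open, as far as these compounds go, is whether either group would give a measured value on the core of compound 1.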